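A Furan-3-yl Replaces 3-Fluorophenyl: Expected Efficacy

This account rests on a few compounds, and the source may have more. Where it says the series, first, only, none or still open, it means among the compounds named here.

Of the compounds shown here, three sharing one core have been tested in an in vitro functional assay on HEK285-7 cells for antagonist activity at prostaglandin D2 receptor 2 (Homo sapiens), read by BRET and beta-arrestin recruitment; a lower number here means a smaller maximal response, a higher number a larger maximal response. Compound 1 `COc1ccc(OC)c(-c2nc(C(c3ccccc3)c3ccccc3)sc2CC(=O)O)c1` gives 80%, compound 2 `O=C(O)Cc1sc(C(c2ccccc2)c2ccccc2)nc1-c1ccc(F)cc1` gives 80%, and compound 3 `O=C(O)Cc1sc(C(c2ccc(F)cc2)c2ccc(F)cc2)nc1-c1cccc(F)c1` gives 80%. Within the data shown here, the one single-point step, no change at the digits printed from compound 1 to compound 2 (within the scatter), is flat. Compound 3 stands level with both: its values and those of compound 1 and compound 2 show no difference beyond the scatter. Compound 4 `O=C(O)Cc1sc(C(c2ccc(F)cc2)c2ccc(F)cc2)nc1-c1ccoc1` differs from compound 3 by furan-3-yl in place of 3-fluorophenyl on an aromatic carbon. The step from compound 1 to compound 2 bears on this, as it swapped the group at the same place and left the maximal response unchanged. Compound 4 is therefore expected to show no step beyond the scatter, no change at the digits printed from compound 3 to compound 4 (within the scatter). Compound 4 is estimated at 80%, with a range from 65% to 93%.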

Compound 4, largest response reached (reported as efficacy), in percent of the reference or control that the assay uses: 80%
The estimate for compound 4 equals the measured number at the digits printed, and the stated range covers the measured number.
By their numbers in this assay, from the lowest: compounds 1, 2, 3 and 4 (each within the scatter of the next).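

In this assay, furan-3-yl in place of 3-fluorophenyl gives no change at the digits printed from compound 3 to compound 4 (within the scatter). The earlier step at this aromatic carbon exchanged one six-membered aromatic ring of carbon only for another, whereas this one brings in a five-membered aromatic ring with 1 hetero atom and 1 hydrogen-bond acceptor, and the maximal response still stays level. No measurement at hand explains why the response stays level here. The compounds shown leave open whether a group that is not an aromatic ring at this place, such as an amine or a longer alkyl chain, would also leave the maximal response level.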